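This account rests on a few compounds, and the source may have more. Where it says the series, first, only, none or still open, it means among the compounds named here.

Measured so far:
compound 1, `Oc1cc(C(F)(F)F)ccc1-c1nc(-c2ccccc2O)n(-c2cccc(Cl)c2)n1`: 72.3%
compound 2, `Oc1cc(C(F)(F)F)ccc1-c1nc(-c2ccccc2O)n(-c2cccc(C(F)(F)F)c2)n1`: 71.5%

Both numbers come from a functional assay on PC-12 cells (Rattus norvegicus) for cytotoxicity, read by MTT assay, with stated times of 2 h and 24 h, tested at 1 uM; on this read-out higher numbers stand for a stronger effect at the one concentration tested and lower numbers for a weaker effect. Compound 2 stands lowest of the two numbers, with compound 1 nearest; the step of a number 0.8 percentage points lower from compound 1 to compound 2 (within the scatter) lies within the scatter, so the two compounds cannot be ordered. Compound 3, `COc1cccc(-n2nc(-c3ccc(C(F)(F)F)cc3O)nc2-c2ccccc2O)c1`, is not yet measured. It differs from compound 2 by methoxy in place of trifluoromethyl on an aromatic carbon, placed on an aromatic carbon of a six-membered aromatic ring of carbon only, meta to a large group. For the measured compounds named here, the only measured step, a number 0.8 percentage points lower from compound 1 to compound 2 (within the scatter), changed the same aromatic carbon and stayed within the scatter; no step with a methoxy entering is known, so it bears on compound 3 only loosely. For compound 3 the expected step of a number 3.5 percentage points lower from compound 2 to compound 3 (within the scatter) is therefore small, with no direction claimed beyond the scatter. Compound 3 is estimated at 68% in this assay, with a range from 52% to 82%.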

Compound 3, a percentage reported as activity, at one concentration (the size of the read-out at that concentration, not a potency): 68.3%
The estimate for compound 3 lay 0.3 percentage points below the measured number; low and high end bracket the measured number.
By their numbers in this assay, from the lowest: compounds 3, 2 and 1 (each within the scatter of the next).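

In this assay, replacing trifluoromethyl with methoxy on this aromatic carbon, meta to a large group, gives a number 3.2 percentage points lower from compound 2 to compound 3 (within the scatter) and replacing chloro with methoxy there gives a number 4 percentage points lower from compound 1 to compound 3 (within the scatter) in the same series. For the compounds shown here, compounds 1 and 2 showed only that one group without a hydrogen-bond acceptor could replace another; with methoxy, a group with a hydrogen-bond acceptor also leaves the read-out within the scatter of both. No supporting measurement explains why these changes leave the read-out so close.

From the compounds shown here alone, whether an amine, a carboxylic acid or a longer alkoxy chain on this carbon would move the read-out beyond the scatter remains open. Also open, going by these compounds, is whether the same changes elsewhere on the shared core, or at other concentrations, would separate the compounds.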